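This account rests on a few compounds, and the source may have more. Where it says the series, first, only, none or still open, it means among the compounds named here.

The series rests on a camphor-derived hydrazone core. Compound 1 `CC1(C)[C@@H]2CC[C@@]1(C)/C(=N/NC(=O)c1ccccc1)C2` carries a benzoyl hydrazide on that core, and in an ADME assay on Vero cells (Chlorocebus sabaeus) for cytotoxicity, read by spectrophotometry, with a stated time of 4 days (a higher number here means that more compound is tolerated, a lower number that less compound is tolerated), compound 1 gives 1430000 nM. Among the measured compounds shown here, it is the only full number in the set. Compound 2 `CC12C=CC3(O1)C(C(=O)N1CCSC13)C2C(=O)N/N=C1\C[C@H]2CC[C@]1(C)C2(C)C` reaches only a limit of the assay, > 250000 nM, so its value is not a number and sets no direction on its own. The set thus holds one compound with a measured value and one at a limit, which is all the evidence there is on cytotoxicity here (the limit of > 250000 nM in this assay, at which 1 of the 2 values shown sits).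

Compound 3 `CC(=O)N/N=C1\C[C@H]2CC[C@]1(C)C2(C)C` differs from compound 1 at a single place: methyl in place of phenyl on a carbonyl carbon. For the measured compounds named here, no measured pair shows the effect of this change, so the size of the step can only be expected. Since compound 1 already tolerates a high concentration, 1430000 nM, compound 3 is expected to sit close by, with a step of a 1.1-fold lower number from compound 1 to compound 3 (0.04 log units; within the scatter) that does not exceed the usual scatter. Compound 3 is therefore estimated at 1300000 nM, within a range from 500000 nM to 3000000 nM.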

Compound 3, half-maximal cytotoxic concentration: > 250000 nM
Compound 3: only a limit was reported (the forecaster's own chance of this, stated with the estimate: 25%); the middle value lies beyond the limit too.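

In this assay compound 3 gives only a limit, > 250000 nM and so no step can be read from compound 1 to compound 3. The compounds shown leave open how far methyl in place of phenyl on a carbonyl carbon moves the tolerated concentration, with the set resting on this: the limit of > 250000 nM in this assay, at which 2 of the 3 values shown sit.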